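Aryl Amide Swap in the Formalin Test

The compounds below may be only part of what the source reports. "The series", "measured", "known", "first", "only" and "open" are said of these compounds alone.

Compound 1, `CCN1CCc2c(c(C(C)(C)C)nn2C(=O)Nc2ccc(Br)cc2)C1`: 72.1%
Compound 2, `CCN1CCc2c(c(C(C)(C)C)nn2C(=O)Nc2ccc(F)cc2F)C1`: 73.4%

In a functional assay on the whole organism (strain Swiss albino) for inhibition, with Mus musculus as the target, in the formalin test, with a stated time of 30 min, at a dose of 100 mg/kg (on this read-out lower numbers stand for less inhibition and higher numbers for more inhibition at the one dose given (going by the name of the read-out)), compound 2 gives 73.4%. Among the compounds with values here, the only step measured so far is a number 1.3 percentage points higher from compound 1 to compound 2 (within the scatter), so the two numbers cannot be told apart, and compound 2 stands with compound 1 rather than apart from it. Compound 3, `CCN1CCc2c(c(C(C)(C)C)nn2C(=O)Nc2cc(C)ccc2F)C1`, differs from compound 2 in one place: 2-fluoro-5-methylphenyl in place of 2,4-difluorophenyl on an amide-type nitrogen. That measured step also swapped the aryl group on the amide-type nitrogen and stayed within the scatter, so for this swap no step beyond the scatter is expected, a number 1.4 percentage points lower from compound 2 to compound 3 (within the scatter). Compound 3 is therefore estimated at 72%, between 60% and 82%.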

Compound 3, a percentage reported as inhibition, in the whole organism at one dose (the size of the read-out at that dose, not a potency): 60.5%
For compound 3 the middle estimate is 11.5 percentage points above the measured one; the measured number falls inside the stated range.
By their numbers in this assay, from the lowest: compound 3; then compounds 1 and 2 (each within the scatter of the next).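

In this assay, the aryl group on this amide-type nitrogen proves not to be interchangeable, which the pair of compound 1 and compound 2 alone did not reveal. Bringing in 2-fluoro-5-methylphenyl gives a clear drop (step: a number 12.9 percentage points lower from compound 2 to compound 3 (beyond the scatter)) and a similar one against the 4-bromophenyl group (step: a number 11.6 percentage points lower from compound 1 to compound 3 (beyond the scatter)). So two quite different aryl groups can read alike here, while a third, with the same count of heavy atoms, reads apart.

As far as these compounds go, how a methoxy group or an amine on this aryl ring would read remains open. Nothing measured here explains the drop.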